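This account rests on a few compounds, and the source may have more. Where it says the series, first, only, none or still open, it means among the compounds named here.

Three compounds sharing one core have been run in a functional assay on HL-60 cells (Homo sapiens) for cytotoxicity, read by CCK-8 assay, with a stated time of 24 h; on this read-out lower numbers stand for stronger inhibition and higher numbers for weaker inhibition. Compound 1 `C=CC(=O)N1C(=O)CC(c2cccc(Cl)c2)Sc2ccccc21` gives 93100 nM, compound 2 `C=CC(=O)N1C(=O)CC(c2ccc(OC)cc2)Sc2ccccc21` gives 92100 nM, and compound 3 `C=CC(=O)N1C(=O)CC(c2ccccc2)Sc2ccccc21` gives 97400 nM. Compound 2 therefore stands among its neighbours with no separation beyond the scatter: the step of a 1.0-fold lower number from compound 1 to compound 2 (0.00 log units; within the scatter) and the step of a 1.1-fold higher number from compound 2 to compound 3 (0.02 log units; within the scatter) are both flat, as is the step of a 1.0-fold higher number from compound 1 to compound 3 (0.02 log units; within the scatter). Compound 4 `C=CC(=O)N1C(=O)CC(c2ccc(Br)cc2)Sc2ccccc21` remains to be measured. Its change from compound 2 is bromo in place of methoxy on an aromatic carbon. Among the measured compounds shown here, the steps that bear on this change are those that exchange the substituent on the pendant aromatic ring, and every one of them, whether chloro, methoxy or hydrogen, left this assay unmoved beyond the scatter. On that basis the step of a 1.0-fold higher number from compound 2 to compound 4 (0.00 log units; within the scatter) is expected to be flat as well. Compound 4 is therefore estimated to give 93000 nM in this assay, with a range from 45000 nM to 190000 nM.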

Compound 4, half-maximal inhibitory concentration: 126000 nM
For compound 4 the middle estimate is 1.4-fold (0.13 log units) below the measured one; the range from low to high includes it.
By their numbers in this assay, from the lowest: compounds 2, 1, 3 and 4 (each within the scatter of the next).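

In this assay the steps of a 1.4-fold higher number from compound 2 to compound 4 (0.14 log units; within the scatter) and a 1.3-fold higher number from compound 3 to compound 4 (0.11 log units; within the scatter) and a 1.4-fold higher number from compound 1 to compound 4 (0.13 log units; within the scatter) all lie within the scatter, so bromo joins methoxy, chloro and hydrogen among the substituents that leave this read-out without a separable change. The exchange at this position takes out a methoxy group that counts one hydrogen-bond acceptor and puts in a single bromine atom that counts none, and even this difference gives no step beyond the scatter. No measurement is available that would account for these numbers.

The compounds shown leave open whether an amine or a carboxylic acid on the pendant ring would move the number beyond the scatter. They also leave open what would happen if the acryloyl group that all four compounds share gave way to a saturated propanoyl group.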